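The compounds below may be only part of what the source reports. "The series", "measured", "known", "first", "only" and "open" are said of these compounds alone.

Measured compounds:
- compound 1, `O=C(COc1cccc2ccccc12)N/N=C/c1ccc(Cl)cc1` — 100 ug/mL in an ADME assay on HEL cells (Homo sapiens) for cytotoxicity; on this read-out higher numbers stand for lower toxicity in this test and lower numbers for higher toxicity in this test
- compound 2, `O=C(COc1cccc2ccccc12)N/N=C/c1ccc(Br)cc1` — 100 ug/mL
- compound 3, `O=C(COc1cccc2ccccc12)N/N=C/c1ccccc1O` — 3.57 ug/mL

Compound 3 stands lowest of the three in this assay; the step of a 28-fold lower number from compound 1 to compound 3 (1.45 log units; beyond the scatter) and the step of a 28-fold lower number from compound 2 to compound 3 (1.45 log units; beyond the scatter) are both large, while no change at the digits printed from compound 1 to compound 2 (within the scatter). Compound 4, `O=C(COc1cccc2ccccc12)N/N=C/c1ccccc1[N+](=O)[O-]`, differs from compound 3 by nitro in place of hydroxy on an aromatic carbon. Among the measured compounds shown here, no measured step exchanges a hydroxy for a nitro, so nothing bears directly on it; the two large steps onto compound 3 show only that changing the substituent on this ring can move this assay a long way. The step of an 8.4-fold higher number from compound 3 to compound 4 (0.92 log units; beyond the scatter) is therefore an expectation with wide uncertainty, and compound 4 is expected to give 30 ug/mL, within 5 ug/mL to 100 ug/mL.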

Compound 4, half-maximal cytotoxic concentration: 100 ug/mL
For compound 4 the middle estimate is 3.3-fold (0.52 log units) below the measured one; measured number inside the range.
By their numbers in this assay, from the lowest: compound 3; then compounds 1, 2 and 4 (each within the scatter of the next).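

In this assay, the nitro group takes the number back up, with a 28-fold higher number from compound 3 to compound 4 (1.45 log units; beyond the scatter) as the step, and compound 4 prints the same value as compound 1 and compound 2. A group on this aromatic carbon, ortho to a large group, therefore does not by itself bring the number down; among these four compounds, the low value occurs only with the hydroxy of compound 3.

From the compounds shown here alone, whether an amine or a methoxy group on this carbon would behave like the hydroxy or like the nitro remains open, as does the effect of a hydroxy elsewhere on the ring. Nothing shown here explains the difference between the hydroxy and the nitro.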